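The source may report more compounds than this note shows. Statements on the series, on what has been measured and on what is new or still open speak of the compounds shown alone.

In an assay on HEK293 cells for positive allosteric modulation of metabotropic glutamate receptor 5 (Homo sapiens), read by FLIPR, with a stated time of 1 h (a higher number here means that more compound is needed for the effect, a lower number that less compound is needed), two compounds have been measured so far.

Compound 1, `CCN1CCc2nc(C#Cc3ccccc3)sc2C1`, gives only the assay limit > 10000 nM.

Compound 2, `COC1CC(C(=O)N2CCc3nc(C#Cc4ccccc4)sc3C2)C1`, gives 640 nM.

Compound 2 thus holds the only real number shown; the other value is a limit (the limit of > 10000 nM in this assay, at which 1 of the 2 values shown sits). Among the compounds with values here, the single measured step, an at least 15-fold lower number from compound 1 to compound 2 (1.19 log units; beyond the scatter), exchanged a simple ethyl group on the ring nitrogen for an amide and moved the number a long way. Compound 3, `O=C(C1CCCCO1)N1CCc2nc(C#Cc3ccccc3)sc2C1`, keeps that amide and differs from compound 2 only in the ring attached to the carbonyl carbon: oxan-2-yl in place of 3-methoxycyclobutyl on a carbonyl carbon. Within the data shown here, no measured step changes just this ring, so there is no direct guide to its size. Since the amide that drove the large step is retained, the expected shift for compound 3 is small, most likely within the scatter, with no clear direction. Compound 3 is therefore expected to give about 800 nM, with a range from 250 nM to 3000 nM. This corresponds to an expected step of a 1.3-fold higher number from compound 2 to compound 3 (0.10 log units; within the scatter).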

Compound 3, half-maximal effective concentration: 320 nM
Estimate against measurement, compound 3: 2.5-fold (0.40 log units) above; low and high end bracket the measured number.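

Exchanging the 3-methoxycyclobutyl group for oxan-2-yl on the carbonyl carbon gives a 2.0-fold lower number from compound 2 to compound 3 (0.30 log units; within the scatter), so this position accepts a different ring size and a different place for the oxygen without a change beyond the scatter. The large gain seen earlier is also no longer tied to one group, as the second amide gives an at least 31-fold lower number from compound 1 to compound 3 (1.49 log units; beyond the scatter). Compound 1 remains a limit and not a number, so the true size of both steps from it stays unknown: the limit of > 10000 nM in this assay, at which 1 of the 3 values shown sits.

The compounds shown leave open whether the oxygen in these rings matters, a question that a plain cyclohexyl ring on the carbonyl carbon could answer. As far as these compounds go, it is also open whether the carbonyl itself is needed, or whether a sulfonyl group or a longer alkyl chain on the amine nitrogen in the ring would serve as well.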